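Gem-dimethyl variant of a homocysteine-derived methyltransferase inhibitor

The source may hold more compounds than are shown below. What is called first, only, known or untested is meant among the compounds shown, and "the series" means these compounds.

Working notes on a short series of homocysteine-derived thioether acids tested in an assay for inhibition of betaine--homocysteine S-methyltransferase 1 (Homo sapiens); on this read-out higher numbers stand for weaker inhibition and lower numbers for stronger inhibition. Compound 1, `CN(CCCSCCC(N)C(=O)O)CC(=O)O`, carries a nitrogen in its chain and in this assay gives "not determined" (no result reported), so it contributes no number to this comparison. For the measured compounds named here, compound 2, `CC(CCSCCC(N)C(=O)O)CC(=O)O`, is the only member with a numerical result: in this assay compound 2 gives 139 nM. Going by the values given here, with a single value there is no ranking and no measured step to draw on.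

Compound 3, `CC(C)(CCSCCC(N)C(=O)O)CC(=O)O`, differs from compound 2 by methyl in place of hydrogen on a saturated chain carbon bound to three saturated chain carbons. Among the compounds with values here, no measured pair shows what such a change does here; the only information is the single value of compound 2 and the small size of the change, one carbon with no donor, acceptor or charge.

The expectation is therefore a step from compound 2 to compound 3 of a 1.2-fold higher number from compound 2 to compound 3 (0.06 log units; within the scatter), not clearly beyond the usual scatter in either direction. On that basis compound 3 is estimated at 160 nM in this assay, with a likely range from 55 nM to 470 nM.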

Compound 3, half-maximal inhibitory concentration: 84 nM
The estimate for compound 3 lay 1.9-fold (0.28 log units) above the measured number; the measured number falls inside the stated range.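

In this assay, for the compounds shown here, the step of a 1.7-fold lower number from compound 2 to compound 3 (0.22 log units; within the scatter) is the first measured pair, and it concerns methyl in place of hydrogen on a saturated chain carbon bound to three saturated chain carbons. Going by these compounds alone, the position therefore accepts this one added carbon with no change in the read-out that can be told from the usual spread of repeated measurements, so compound 2 and compound 3 stand as equivalent on this assay, something the single earlier number could not show. No supporting data are available to explain this step or to tie it to any property of the methyl group.

On these data alone, whether an ethyl group, a hydroxyl group or an amine on the same carbon would stay equally close to compound 2 remains open, as does the effect of a longer chain on the shared core. Compound 1 gives "not determined" (no result reported) and so offers no number for comparison, which leaves the effect of a nitrogen in the chain unresolved in this assay as well.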